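Changing the Ring on a Shared Core: Compound 4

The source may hold more compounds than are shown below. What is called first, only, known or untested is meant among the compounds shown, and "the series" means these compounds.

Compound 1 `Cn1c(=O)c(=O)n(C2CCCC2)c2nc(N/N=C/c3ccc(O)cc3)ncc21`: 72500 nM
Compound 2 `Cn1c(=O)c(=O)n(C2CCCC2)c2nc(N/N=C/c3ccc(S(C)(=O)=O)cc3)ncc21`: 86600 nM
Compound 3 `Cn1c(=O)c(=O)n(C2CCCC2)c2nc(N/N=C/c3ccc(F)cc3Cl)ncc21`: 13800 nM

In a functional assay on HCT-116 cells (Homo sapiens) for antiproliferative activity, read by MTT assay (a higher number here means a weaker inhibitor, a lower number a stronger inhibitor), compound 1 stands second highest of the three numbers; compound 2 lies within the scatter of it, while compound 3 sits well below it. Compound 4 `Cn1c(=O)c(=O)n(C2CCCC2)c2nc(N/N=C/c3cc([N+](=O)[O-])ccc3Cl)ncc21` differs from compound 1 in one place: 2-chloro-5-nitrophenyl in place of 4-hydroxyphenyl on a carbon with a double bond to nitrogen. The step that bears on this change is a 5.3-fold lower number from compound 1 to compound 3 (0.72 log units; beyond the scatter), where a ring carrying chlorine and fluorine replaced the 4-hydroxyphenyl; a 6.3-fold lower number from compound 2 to compound 3 (0.80 log units; beyond the scatter) points the same way. Compound 4 likewise carries a chlorine on its ring, as compound 3 does, so a modest downward step is expected, roughly a 4.0-fold lower number from compound 1 to compound 4 (0.61 log units; beyond the scatter). For compound 4 the expected value is 18000 nM, with a range from 6000 nM to 50000 nM.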

Compound 4, half-maximal inhibitory concentration: 5610 nM
Compound 4: middle estimate off by 3.2-fold (0.51 log units), on the high side, and the stated range ends above it.
By their numbers in this assay, from the lowest: compound 4; then compound 3; then compounds 1 and 2 (each within the scatter of the next).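

With 2-chloro-5-nitrophenyl on this carbon the steps become large (a 13-fold lower number from compound 1 to compound 4 (1.11 log units; beyond the scatter)) and (a 15-fold lower number from compound 2 to compound 4 (1.19 log units; beyond the scatter)), so changing this ring can move the number further than compound 3 had shown. Two rings that both carry a 2-chloro group still differ (a 2.5-fold lower number from compound 3 to compound 4 (0.39 log units; beyond the scatter)), so the chlorine alone does not set the number. No measurement available here explains why these rings differ.

Going by these compounds, whether a nitro group without the chlorine would give the same result remains open, as does the effect of an amine or a carboxylic acid on this ring.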